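Swapping chloro for trifluoromethyl on a chemokine receptor ligand

The compounds below may be only part of what the source reports. "The series", "measured", "known", "first", "only" and "open" are said of these compounds alone.

Measured compounds:
- compound 1, `CC[C@H]1CN(c2ncc(C(N)=O)nc2Cl)CCN1C1CCN(C(=O)c2ccc(Cl)nc2N)CC1`: 2.5 nM
- compound 2, `CC[C@H]1CN(c2ncc(C(=O)NCCO)nc2Cl)CCN1C1CCN(C(=O)c2ccc(Cl)nc2N)CC1`: 2.9 nM

In an in vitro assay on BaF3 cells for displacement of a labelled ligand from C-X-C chemokine receptor type 3 (Homo sapiens) (on this read-out higher numbers stand for weaker inhibition and lower numbers for stronger inhibition), compound 1 gives 2.5 nM, the lowest of the two numbers shown. Compound 2, which carries a 2-hydroxyethyl group in place of hydrogen on an amide-type nitrogen, gives 2.9 nM in this assay, and the move a 1.2-fold higher number from compound 1 to compound 2 (0.06 log units; within the scatter) stays within the scatter. Compound 3, `CC[C@H]1CN(c2ncc(C(N)=O)nc2C(F)(F)F)CCN1C1CCN(C(=O)c2ccc(Cl)nc2N)CC1`, has not yet been measured. It differs from compound 1 in this way: trifluoromethyl in place of chloro on an aromatic carbon, next to the ring nitrogen and meta to a carbamoyl group. Neither measured step touches this position, so nothing measured here bears directly on the change. On that basis the estimate for compound 3 is a modest step, a 1.8-fold higher number from compound 1 to compound 3 (0.26 log units; within the scatter), towards a somewhat higher number. Compound 3 is therefore expected to give about 4.5 nM in this assay, within a range from 1.3 nM to 15 nM.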

Compound 3, half-maximal inhibitory concentration: 1.9 nM
Beside the measured number, compound 3's estimate is 2.4-fold (0.37 log units) above it, within the range that was stated.
By their numbers in this assay, from the lowest: compounds 3, 1 and 2 (each within the scatter of the next).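

Trifluoromethyl on this aromatic carbon, next to the ring nitrogen, brings 4 heavy atoms where chloro had 1, and in this assay the swap gives a 1.3-fold lower number from compound 1 to compound 3 (0.12 log units; within the scatter) as its whole effect on the read-out. Among the compounds shown here, the earlier step changed only the amide-type nitrogen, so this is the first look at this position: here chloro can give way to the larger trifluoromethyl with no difference beyond the scatter. Nothing measured here explains why the two groups read alike.

On these data alone, whether this holds for other kinds of group at this position stays open, for example a methyl, a methoxy, a nitrile or a dimethylamino group. Also open, as far as these compounds go, is whether trifluoromethyl would read the same alongside the 2-hydroxyethyl group of compound 2.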